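Bis-indolyl methanes: moving from dimethoxyphenyl to chlorophenyl

The source may hold more compounds than are shown below. What is called first, only, known or untested is meant among the compounds shown, and "the series" means these compounds.

Measured so far in a functional assay on MCF7 cells (Homo sapiens) for inhibition, read by MTT assay, with a stated time of 48 h; a lower number here means a stronger inhibitor, a higher number a weaker inhibitor:
compound 1, `Brc1ccc2[nH]cc(C(c3ccccc3)c3c[nH]c4ccc(Br)cc34)c2c1`: 5500 nM
compound 2, `Oc1cccc(C(c2c[nH]c3ccc(Br)cc23)c2c[nH]c3ccc(Br)cc23)c1`: 2800 nM
compound 3, `COc1ccc(C(c2c[nH]c3ccc(Br)cc23)c2c[nH]c3ccc(Br)cc23)c(OC)c1`: 77500 nM

Compound 3 is the weakest of the three in this assay: its nearest neighbour, compound 1, sits a 14-fold higher number from compound 1 to compound 3 (1.15 log units; beyond the scatter) away in the other direction, and the wider gap is a 28-fold higher number from compound 2 to compound 3 (1.44 log units; beyond the scatter), so the dimethoxy-bearing aryl group marks the high end of the numbers seen so far. Compound 4, `Clc1ccc(C(c2c[nH]c3ccc(Br)cc23)c2c[nH]c3ccc(Br)cc23)cc1`, differs from compound 3 in one place: 4-chlorophenyl in place of 2,4-dimethoxyphenyl on a saturated chain carbon bound to two aromatic carbons. The change returns the central carbon to a phenyl ring carrying a single halogen, closer to compound 1 than to compound 3. Among the measured compounds shown here, the steps that bear on it are the two large rises into compound 3, and reversing that pattern should mean a large fall. Compound 4 is therefore expected to give about 5000 nM in this assay, between 1500 nM and 16000 nM, an estimated step of a 16-fold lower number from compound 3 to compound 4 (1.19 log units; beyond the scatter).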

Compound 4, half-maximal inhibitory concentration: 3500 nM
Compound 4: middle estimate off by 1.4-fold (0.15 log units), on the high side, within the range that was stated.
By their numbers in this assay, from the lowest: compounds 2, 4 and 1 (each within the scatter of the next); then compound 3.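

In this assay, 4-chlorophenyl in place of 2,4-dimethoxyphenyl on the saturated chain carbon gives a large fall (a 22-fold lower number from compound 3 to compound 4 (1.35 log units; beyond the scatter)), so the high number of compound 3 does not extend to this halogen-bearing ring. The chloro group makes no difference that can be read from the unsubstituted phenyl (a 1.6-fold lower number from compound 1 to compound 4 (0.20 log units; within the scatter)), nor does 4-chlorophenyl differ readably from 3-hydroxyphenyl (a 1.3-fold higher number from compound 2 to compound 4 (0.10 log units; within the scatter)), leaving only the 2,4-dimethoxyphenyl group apart among these four compounds. Nothing available explains this separation.

On these data alone, whether a single methoxy group would be enough to produce the high number remains open, as does how an amine or a carboxylic acid on this phenyl ring would read.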